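A few compounds are considered here, and "the series" means these few. Any claim that something is new, unique, unknown or untested is made for them only; others in the source may bear on it.

The series shares one core, seen in compound 1 `CCCn1nc(-c2cccnc2)c2ccccc2c1=O`, which in a functional assay (trachea) with Cavia porcellus as the target (on this read-out lower numbers stand for stronger inhibition and higher numbers for weaker inhibition), gives 3160 nM. Compound 2 `CCCCn1nc(-c2cccnc2)c2ccccc2c1=O` gives 2290 nM in this assay, and compound 3 `CCCCCCCCn1nc(-c2cccnc2)c2ccccc2c1=O` gives 21900 nM. Compound 3 stands highest of the three numbers in this assay; its nearest neighbour is compound 1, and the move a 6.9-fold higher number from compound 1 to compound 3 (0.84 log units; beyond the scatter), while a 9.6-fold higher number from compound 2 to compound 3 (0.98 log units; beyond the scatter). The move a 1.4-fold lower number from compound 1 to compound 2 (0.14 log units; within the scatter) stayed within the scatter. Compound 4 `CCOC(=O)CCCn1nc(-c2cccnc2)c2ccccc2c1=O` differs from compound 3 in one place: ethoxycarbonyl in place of pentyl on a saturated chain carbon, three bonds along the chain from an aromatic nitrogen. Among the measured compounds shown here, no measured pair shows this exchange directly; the steps that bear on it are those in which the chain on the same position was lengthened, from compound 1 and compound 2 to compound 3, both modest and both toward higher numbers. Since compound 4 keeps a chain of the same heavy-atom count as compound 3 but ends it in a group with two acceptors, the account expects a modest step back toward compound 1, with wide uncertainty. The estimate for compound 4 in this assay is 7000 nM, between 2000 nM and 25000 nM, meaning an expected 3.1-fold lower number from compound 3 to compound 4 (0.50 log units; beyond the scatter).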

Compound 4, half-maximal inhibitory concentration: 10000 nM
Beside the measured number, compound 4's estimate is 1.4-fold (0.15 log units) below it, and the stated range covers the measured number.
By their numbers in this assay, from the lowest: compounds 2 and 1 (each within the scatter of the next); then compound 4; then compound 3.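

In this assay, the exchange of pentyl for ethoxycarbonyl at this position leaves the heavy-atom count unchanged yet still moves the number (a 2.2-fold lower number from compound 3 to compound 4 (0.34 log units; beyond the scatter)), so chain length alone does not set the result here. Among the compounds shown here, the earlier compounds showed only changes in plain alkyl chains, whereas this is the first sign that what ends the chain matters as well. Compound 4 recovers only part of the loss seen with the octyl chain, however, and remains weaker than both short-chain compounds (a 4.4-fold higher number from compound 2 to compound 4 (0.64 log units; beyond the scatter); a 3.2-fold higher number from compound 1 to compound 4 (0.50 log units; beyond the scatter)). Nothing shown explains why the ethoxycarbonyl chain behaves this way.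

As far as these compounds go, it remains open whether a carboxylic acid, an amide or an amine at the end of this chain would act like ethoxycarbonyl. From the compounds shown here alone, it is also open whether a shorter (ethoxycarbonyl)methyl or 2-(ethoxycarbonyl)ethyl group would come closer to the short-chain compounds.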